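This account rests on a few compounds, and the source may have more. Where it says the series, first, only, none or still open, it means among the compounds named here.

Working notes on the phenoxyaniline series, shared core as in compound 1 `CC(Nc1ccccc1Oc1ccc(Cl)cc1)=C1C(=O)CC(c2ccccc2)CC1=O`. In a functional assay on HMEC-1 cells (Homo sapiens) for antiproliferative activity, read by cell counting, with a stated time of 4 days (on this read-out higher numbers stand for weaker inhibition and lower numbers for stronger inhibition), compound 1 gives 260 nM. Compound 2 `COc1ccc(Oc2ccccc2NC(C)=C2C(=O)CC(c3ccccc3)CC2=O)cc1` gives 83 nM, and compound 3 `CC(Nc1ccccc1Oc1ccccc1)=C1C(=O)CC(c2ccccc2)CC1=O` gives 160 nM. Compound 3 thus stands second highest of the three numbers; its gap to compound 1, a 1.6-fold lower number from compound 1 to compound 3 (0.21 log units; within the scatter), is within the scatter, as is its gap to compound 2, a 1.9-fold higher number from compound 2 to compound 3 (0.29 log units; within the scatter). For the measured compounds named here, the only step beyond the scatter so far is a 3.1-fold lower number from compound 1 to compound 2 (0.50 log units; beyond the scatter), a modest one.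

Compound 4 `COc1cccc(Oc2ccccc2NC(C)=C2C(=O)CC(c3ccccc3)CC2=O)c1` is the next analogue. Relative to compound 3 the change is methoxy in place of hydrogen on an aromatic carbon; the phenoxy becomes a 3-methoxyphenoxy, the methoxy sitting meta to a large group. The step that bears on this is a 1.9-fold higher number from compound 2 to compound 3 (0.29 log units; within the scatter), where a methoxy on the same ring is removed and the number moves only within the scatter. As far as these compounds go, compound 2 carries its methoxy elsewhere on that ring, so the position in compound 4 is untested. Reading the one available step backwards, a methoxy entering is expected to lower the number, if at all, by a small amount, and the expected step of a 1.4-fold lower number from compound 3 to compound 4 (0.14 log units; within the scatter) should stay within the scatter. For compound 4 the estimate is 115 nM, with a range of 50 nM to 270 nM.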

Compound 4, half-maximal inhibitory concentration: 59 nM
The estimate for compound 4 lay 1.9-fold (0.29 log units) above the measured number; the range from low to high includes it.
By their numbers in this assay, from the lowest: compounds 4, 2, 3 and 1 (each within the scatter of the next, the first and the last beyond it).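

Placing a methoxy on the unsubstituted phenoxy ring gives a step beyond the scatter (a 2.7-fold lower number from compound 3 to compound 4 (0.43 log units; beyond the scatter)), whereas the step between compound 2 and compound 3 stayed within it, so this place on the ring responds to the change in a way the earlier compounds did not show. For the compounds shown here, the 3-methoxyphenyl and 4-methoxyphenyl forms cannot be separated (a 1.4-fold lower number from compound 2 to compound 4 (0.15 log units; within the scatter)), so the data rank neither methoxy place above the other, while 3-methoxyphenyl in place of 4-chlorophenyl gives the largest step so far (a 4.4-fold lower number from compound 1 to compound 4 (0.64 log units; beyond the scatter)). Nothing at hand accounts for the lower number at this place.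

As far as these compounds go, it remains open whether a chloro, an amine or a carboxylic acid at the place of the methoxy in compound 4 would keep the number at this level, and whether a longer chain such as ethoxy would do the same. Also open, from the compounds shown here alone, is whether the oxygen of the methoxy matters, which an ethyl group at that same place would help to settle.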